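This account rests on a few compounds, and the source may have more. Where it says the series, first, only, none or still open, it means among the compounds named here.

Compound 1 `Cc1ccnc(-c2ccccc2OCC2=NCCN2)c1`, compound 2 `c1cnc(-c2ccccc2OCC2=NCCN2)nc1` and compound 3 `c1ccc(-c2ccncn2)c(OCC2=NCCN2)c1` share a core and differ only in the aromatic group attached to it. In a functional assay for activation of Alpha-1B adrenergic receptor (Homo sapiens), read by calcium flux (on this read-out higher numbers stand for an effect only at larger amounts of compound and lower numbers for an effect already at smaller amounts), compound 1 gives < 100000 nM, which is a limit of the assay and not a number. Compound 2 gives < 100000 nM in this assay, again a limit of the assay. Compound 3 stands at < 100000 nM in this assay, likewise a limit of the assay. As far as these compounds go, the step that the two limits leave unreadable from compound 2 to compound 3 cannot be read because the limit of < 100000 nM in this assay, at which 3 of the 3 values shown sit, covers every value shown, so the size of the change from pyrimidin-2-yl to pyrimidin-4-yl stays unknown.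

Compound 4 `c1ccc(-c2ccoc2)c(OCC2=NCCN2)c1` differs from compound 3 by furan-3-yl in place of pyrimidin-4-yl on an aromatic carbon. Going by the values given here, no measured step bears on this change with a readable size, since all three compounds sit at the same limit. The step that the limit leaves unreadable from compound 3 to compound 4 is therefore expected to be small and of no clear direction, within the scatter. Compound 4 is estimated at 5000 nM in this assay, with a range from 300 nM to 80000 nM.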

Compound 4, half-maximal effective concentration: 5.01 nM
Estimate against measurement, compound 4: 1000-fold (3.00 log units) above, outside the stated range (below it).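

No step from compound 2 or compound 3 to compound 4 can be read in this assay, because both earlier compounds carry only a limit: the limit of < 100000 nM in this assay, at which 3 of the 4 values shown sit.

The compounds shown leave open what furan-3-yl in place of pyrimidin-4-yl or pyrimidin-2-yl actually does to the value.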